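Sulfanyl Swapped for a Diamine Chain on an Unchanged Core

The compounds below may be only part of what the source reports. "The series", "measured", "known", "first", "only" and "open" are said of these compounds alone.

Compound 1 `Sc1nncc2cncn12` gives > 48000 nM in a functional assay for inhibition, with Homo sapiens as the target (on this read-out lower numbers stand for stronger inhibition and higher numbers for weaker inhibition), which is a limit of the assay and not a number.
Compound 2 `COCc1ncc2cnnc(S)n12` gives > 48000 nM in this assay, again a limit rather than a number.
Compound 3 `CCCc1ncc2cnnc(S)n12` gives > 48000 nM in this assay, also a limit.

Compound 2 therefore stands where both of its neighbours stand, at the limit of > 48000 nM in this assay, at which 3 of the 3 values shown sit, so the numbers shown place it neither above nor below them. Compound 4 `COCc1ncc2cnnc(NCCN(C)C)n12` keeps the core of compound 2 and differs from it in one place: (2-(dimethylamino)ethyl)amino in place of sulfanyl on an aromatic carbon. For the measured compounds named here, no measured step touches that group. The steps a step that the two limits leave unreadable from compound 1 to compound 2 and a step that the two limits leave unreadable from compound 1 to compound 3 concern a substituent on another aromatic carbon, the step that the two limits leave unreadable from compound 2 to compound 3 a swap within that substituent, and all three remain unreadable. They give neither a direction nor a size for the move to compound 4 in this assay.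

For compound 4 the expected value is 40000 nM, with an estimated range from 4000 nM to 300000 nM. Going by the values given here, that expectation amounts to an estimated step of an at least 1.2-fold lower number from compound 2 to compound 4 (0.07 log units; that floor lies within the scatter), resting on no measured step at all.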

Compound 4, half-maximal inhibitory concentration: > 48000 nM
Compound 4 was reported as a limit; the forecaster's own chance of this, stated with the estimate: 60%; middle value at least 1.2-fold (0.07 log units) away from the limit.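

For the compounds shown here, compound 4, like compound 2, is reported only as a limit in this assay, so the step between them cannot be read and this result yields no new step. The compounds shown leave open how strongly any of them inhibits, and whether (2-(dimethylamino)ethyl)amino in place of sulfanyl changes the read-out at all.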